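A few compounds are considered here, and "the series" means these few. Any claim that something is new, unique, unknown or untested is made for them only; others in the source may bear on it.

Of the compounds shown here, two on a shared core have been read in a functional assay on MIA PaCa-2 cells (Homo sapiens) for inhibition, read by MTT assay, with a stated time of 48 h, tested at 10 uM; a higher number here means more inhibition of growth at the concentration tested, a lower number less inhibition of growth. Compound 1 (`Cc1cc(=O)c2c(O)c(CN3CCC(c4ccccc4)CC3)c(O)c([C@H]3CCN(C)C[C@H]3O)c2o1`) gives 16% and compound 2 (`Cc1oc2c([C@H]3CCN(C)C[C@H]3O)c(O)cc(O)c2c(=O)c1C(O)c1ccc(F)c(Br)c1`) gives 9%. These two values stand within the scatter of each other, and both mark little growth inhibition at the concentration tested. Compound 3 (`COc1ccc(C(O)c2c(C)oc3c([C@H]4CCN(C)C[C@H]4O)c(O)cc(O)c3c2=O)cc1Br`) differs from compound 2 in one place: methoxy in place of fluoro on an aromatic carbon. Methoxy stands in place of fluoro on an aromatic carbon, ortho to a bromo group, so that 3-bromo-4-fluorophenyl becomes 3-bromo-4-methoxyphenyl. Among the compounds with values here, no measured pair shows this change. With compound 2 at 9% as the starting point, no step beyond the scatter is expected in this assay, in either direction. The estimated step is a number 3 percentage points higher from compound 2 to compound 3 (within the scatter). For compound 3 the expected value is 12%, with an estimated range from 2% to 25%.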

Compound 3, percent growth inhibition at one concentration: 3%
Compound 3: the middle estimate sits 9 percentage points above what was measured; measured number inside the range.
By their numbers in this assay, from the lowest: compounds 3, 2 and 1 (each within the scatter of the next, the first and the last beyond it).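

In this assay, within the data shown here, methoxy in place of fluoro on the aromatic carbon ortho to the bromo group gives the first measured step at this position (a number 6 percentage points lower from compound 2 to compound 3 (within the scatter)). Compound 2 and compound 3 therefore both mark little growth inhibition at the concentration tested, and this exchange of two groups does not separate them in this read-out. No measurement at hand bears on this result.

The compounds shown leave open whether a different group at this position, such as an amine or a carboxylic acid, would give a step beyond the scatter. They also leave open whether the methoxy group would read the same with hydrogen in place of the bromo group.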